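Propyl in Place of Phenyl on the Acid Chain

A few compounds are considered here, and "the series" means these few. Any claim that something is new, unique, unknown or untested is made for them only; others in the source may bear on it.

Measured in an assay on membranes from lung (Cavia porcellus) for binding affinity to cysteinyl leukotriene receptor (Homo sapiens); a higher number here means a weaker inhibitor, a lower number a stronger inhibitor:
Compound 1, `CC(CCc1ccc(OCc2ccc3ccccc3n2)cc1)Cc1nnn[nH]1`: 25 nM
Compound 2, `O=C(O)CC1CCCC1Cc1ccc(OCc2ccc3ccccc3n2)cc1`: 100 nM
Compound 3, `O=C(O)CCC(Cc1ccc(OCc2ccc3ccccc3n2)cc1)c1ccccc1`: 31 nM

Compound 3 stands second highest of these three numbers. Among the measured compounds shown here, its value lies within the usual scatter of compound 1, while compound 2 sits beyond it; the only measured single step is a 4.0-fold higher number from compound 1 to compound 2 (0.60 log units; beyond the scatter). Compound 4, `CCCC(CCC(=O)O)Cc1ccc(OCc2ccc3ccccc3n2)cc1`, differs from compound 3 by propyl in place of phenyl on a saturated chain carbon bound to two saturated chain carbons. For the measured compounds named here, no measured step covers this change; the step from compound 1 to compound 2 concerns another part of the chain and gives no direct guide. Compound 1 and compound 3 carry different groups on that chain yet give values within scatter of each other, so no large shift is expected. Compound 4 is therefore estimated at 45 nM, between 15 nM and 150 nM. The expected step is a 1.5-fold higher number from compound 3 to compound 4 (0.16 log units; within the scatter), likely within the scatter.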

Compound 4, inhibition constant: 21 nM
Compound 4: middle estimate off by 2.1-fold (0.33 log units), on the high side; the measured number falls inside the stated range.
By their numbers in this assay, from the lowest: compounds 4, 1 and 3 (each within the scatter of the next); then compound 2.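

In this assay propyl in place of phenyl gives a 1.5-fold lower number from compound 3 to compound 4 (0.17 log units; within the scatter) on this saturated chain carbon bound to two saturated chain carbons, so here an open chain can stand in for the aromatic ring without a shift beyond the scatter. The 1-(2-carboxyethyl)butyl group gives a 4.8-fold lower number from compound 2 to compound 4 (0.68 log units; beyond the scatter) against the 2-(carboxymethyl)cyclopentyl group and a 1.2-fold lower number from compound 1 to compound 4 (0.08 log units; within the scatter) against the 2-((1H-tetrazol-5-yl)methyl)propyl group, so it clearly differs from the former but not from the latter. No supporting data explain these steps.

From the compounds shown here alone, how methyl, a longer chain such as hexyl, or an amine would fare on this carbon remains open.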